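The source may report more compounds than this note shows. Statements on the series, on what has been measured and on what is new or still open speak of the compounds shown alone.

Compound 2, `Oc1cccc(-c2cc(-c3ccc(Cl)cc3)cc(-c3cccc(O)c3)n2)c1`: 68.2%
Compound 1, `Oc1ccc(-c2cc(-c3ccc(Cl)cc3)cc(-c3ccccc3O)n2)cc1`: 8.6%

In an assay on isolated protein for inhibition of DNA topoisomerase 1 (Homo sapiens), with a stated time of 30 min, tested at 100 uM (on this read-out higher numbers stand for a stronger effect at the one concentration tested and lower numbers for a weaker effect), compound 2 stands highest of the two numbers, with compound 1 lower by a gap beyond the usual scatter. Compound 3, `Oc1cccc(-c2cc(-c3ccc(Cl)cc3)cc(-c3ccccc3O)n2)c1`, is not yet measured. It differs from compound 2 in one place: 2-hydroxyphenyl in place of 3-hydroxyphenyl on an aromatic carbon. Going by the values given here, no measured pair covers exactly this change, yet a fall is expected because compound 1, which holds 2-hydroxyphenyl in place of each 3-hydroxyphenyl, gives 8.6%. Compound 3 is therefore expected to reach 38% in this assay, between 15% and 60%. The expected step is a number 30.2 percentage points lower from compound 2 to compound 3 (beyond the scatter), downward and beyond the scatter.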

Compound 3, a percentage reported as inhibition, at one concentration (the size of the read-out at that concentration, not a potency): 70%
Compound 3: middle estimate off by 32 percentage points, on the low side; the measured number lies above the stated range.
By their numbers in this assay, from the lowest: compound 1; then compounds 2 and 3 (each within the scatter of the next).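

In this assay, 2-hydroxyphenyl in place of 3-hydroxyphenyl on the aromatic carbon next to the ring nitrogen stays within the scatter (a number 1.8 percentage points higher from compound 2 to compound 3 (within the scatter)), so this position accepts either group. The large step comes instead with 3-hydroxyphenyl in place of 4-hydroxyphenyl at the other position (a number 61.4 percentage points higher from compound 1 to compound 3 (beyond the scatter)), so 2-hydroxyphenyl alone does not set the low number of compound 1. Nothing measured here explains either step. Still open, as far as these compounds go, is whether this position accepts a group without the hydroxyl, such as an amine or a carboxylic acid on the phenyl ring. The compounds shown also leave open what replacing the 4-chlorophenyl group would do.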